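The compounds below may be only part of what the source reports. "The series", "measured", "known", "first", "only" and "open" are said of these compounds alone.

Measured so far in a functional assay on the whole organism for agonist activity, with Mus musculus as the target; on this read-out higher numbers stand for an effect only at larger amounts of compound and lower numbers for an effect already at smaller amounts:
- Compound 1 `CC(=O)N(C)CC#CCn1cncc1C`: > 100 mg/kg (a limit)
- Compound 2 `CCOC(=O)N(C)CC#CCn1ccnc1`: > 100 mg/kg (a limit)

Compound 2 gives no number on this read-out, only the limit > 100 mg/kg. The other reading in the series is a limit too, so the evidence so far amounts to the limit of > 100 mg/kg in this assay, at which 2 of the 2 values shown sit. Within the data shown here, no pair of measured compounds differs in one place, and the series therefore offers no measured step to build on.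

Compound 3 `CCOC(=O)N(C)CC#CCn1cncc1C` is compound 2 with methyl in place of hydrogen on an aromatic carbon. Compound 1 already carries this methyl, and its > 100 mg/kg is again a limit. Having the methyl therefore did not bring a numerical reading in that one case, although compound 1 also differs from compound 3 elsewhere. In this assay no step beyond the scatter is expected, and no direction can be assigned. The expected change is a step that the limit leaves unreadable from compound 2 to compound 3, an estimate that stays within the scatter. The assay may well report only a limit again. For compound 3 the estimated value is 150 mg/kg, with an expected range of 60 mg/kg to 400 mg/kg.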

Compound 3, dose for half-maximal effect: > 100 mg/kg
Compound 3: no number, only a limit; the forecaster's own chance of this, stated with the estimate: 75%; the middle value is on the limit's open side.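

In this assay neither the step from compound 2 to compound 3 nor the step from compound 1 to compound 3 can be read, as all three readings are limits and not numbers: the limit of > 100 mg/kg in this assay, at which 3 of the 3 values shown sit.

The compounds shown leave open whether methyl in place of hydrogen on an aromatic carbon, or ethoxy in place of methyl on a carbonyl carbon, changes the read-out at all.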